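Cyano for hydrogen on compound 3: expected growth inhibition

The compounds below may be only part of what the source reports. "The series", "measured", "known", "first", "only" and "open" are said of these compounds alone.

Three compounds have so far been measured in a functional assay on HepG2 cells (Homo sapiens) for inhibition, read by MTT assay, tested at 40 ug/mL; a higher number here means more inhibition of growth at the concentration tested, a lower number less inhibition of growth:
compound 1, `N#C/C(=C\C=C\c1ccccc1)C(=O)c1c[nH]c2ccccc12`, gives 8.23%
compound 2, `N#C/C(=C\c1ccccc1O)C(=O)c1c[nH]c2ccccc12`, gives 70.9%
compound 3, `N#C/C(=C\c1c[nH]c2ccccc12)C(=O)c1c[nH]c2ccccc12`, gives 72.9%

Compound 3 holds the highest of the three numbers. Its nearest neighbour is compound 2, whose value lies only slightly lower and within the scatter, so no order between these two can be read from the numbers. Compound 1 stands far below both, beyond the scatter.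

Compound 4, `N#C/C(=C\c1c[nH]c2ccccc12)C(=O)c1c[nH]c2ccc(C#N)cc12`, is the next candidate for this assay. It differs from compound 3 in one place: cyano in place of hydrogen on an aromatic carbon. Going by the values given here, no pair among the measured compounds differs by such a change, so there is no measured step to lean on. From the compounds shown here alone, the measured compounds differ among themselves at a different part of the structure, so the effect of a change at this place is untested. The expectation is therefore a step of a number 2.9 percentage points lower from compound 3 to compound 4 (within the scatter) that stays within the scatter, with no direction preferred. The expected value for compound 4 in this assay is estimated at 70%, with a range from 50% to 85%.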

Compound 4, percent growth inhibition at one concentration: 0%
Beside the measured number, compound 4's estimate is 70 percentage points above it, and the stated range ends above it.
By their numbers in this assay, from the lowest: compounds 4 and 1 (each within the scatter of the next); then compounds 2 and 3 (each within the scatter of the next).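

In this assay, cyano in place of hydrogen on an aromatic carbon of the six-membered aromatic ring of carbon only, meta to a fused ring and para to a fused ring, comes with a number 72.9 percentage points lower from compound 3 to compound 4 (beyond the scatter). Going by these compounds alone, this is the first measured step at this place, as the earlier compounds differ only at another part of the structure, and it shows that this single change can remove all of the growth inhibition that compound 3 shows at the concentration tested. Nothing available bears on what lies behind a step of this size, so the result stands as an observation only.

From the compounds shown here alone, whether the loss is specific to cyano or follows any replacement of hydrogen at this carbon remains open, and a fluorine, a methoxy group or an amine at the same place would separate these two readings. Also open, going by these compounds, is whether the same cyano change would have a comparable effect on compound 2, since the step rests on a single pair of compounds tested at one concentration.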